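The compounds below may be only part of what the source reports. "The series", "measured", "known", "first", "only" and "open" are said of these compounds alone.

Measured in an ADME assay on Vero cells (Chlorocebus sabaeus) for cytotoxicity, read by MTT assay, with a stated time of 48 h; a higher number here means that more compound is tolerated, a lower number that less compound is tolerated:
- Compound 1 `COc1ccc(C(C)(C)NC(=O)c2ccc([N+](=O)[O-])o2)cc1`: 82000 nM
- Compound 2 `CC(C)(NC(=O)c1ccc([N+](=O)[O-])o1)c1ccc(C#N)cc1`: 83000 nM
- Compound 3 `CC(C)(NC(=O)c1ccc([N+](=O)[O-])o1)c1ccc(-c2ccc(Cl)cc2)cc1`: > 140000 nM

Compound 3 is known only through a limit of the assay, > 140000 nM, and not through a number. Compound 4 `CC(C)(NC(=O)c1ccc([N+](=O)[O-])o1)c1ccc(COc2ccc(Cl)cc2)cc1` has not yet been measured. It carries (4-chlorophenoxy)methyl in place of 4-chlorophenyl on an aromatic carbon, para to a large group: (4-chlorophenoxy)methyl in place of 4-chlorophenyl on an aromatic carbon.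

Three measured changes on that same aromatic carbon bear on this one: a 1.0-fold higher number from compound 1 to compound 2 (0.01 log units; within the scatter), an at least 1.7-fold higher number from compound 1 to compound 3 (0.23 log units; that floor lies within the scatter) and an at least 1.6-fold higher number from compound 2 to compound 3 (0.22 log units; that floor lies within the scatter). The last two rest on the limit of compound 3, so they give only floors. None of the three goes beyond the scatter, so no step beyond the scatter is expected in this assay, and another limit reading would not be surprising.

The estimated step is an at least 1.2-fold lower number from compound 3 to compound 4 (0.10 log units; that floor lies within the scatter). For compound 4 the expected value is 110000 nM, with an estimated range from 45000 nM to 220000 nM.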

Compound 4, half-maximal cytotoxic concentration: 120000 nM
For compound 4 the middle estimate is 1.1-fold (0.04 log units) below the measured one, within the range that was stated.
By their numbers in this assay, from the lowest: compounds 1, 2 and 4 (each within the scatter of the next). At a limit, above all of these: compound 3.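

In this assay, (4-chlorophenoxy)methyl on this aromatic carbon, para to a large group, gives a number rather than a limit, and the steps, a 1.5-fold higher number from compound 1 to compound 4 (0.17 log units; within the scatter) and a 1.4-fold higher number from compound 2 to compound 4 (0.16 log units; within the scatter), stay within the scatter. Methoxy, cyano and (4-chlorophenoxy)methyl therefore all sit at this position without a step beyond the scatter. The change from 4-chlorophenyl, an at least 1.1-fold lower number from compound 3 to compound 4 (0.06 log units; that floor lies within the scatter), can be read only as a floor, since the starting compound is known only by a limit of the assay: the limit of > 140000 nM in this assay, at which 1 of the 4 values shown sits.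

As far as these compounds go, whether an amine or a carboxylic acid on this carbon would move the number beyond the scatter stays open. So does the actual number behind the limit of compound 3, and with it the true size of this change.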